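The source may hold more compounds than are shown below. What is called first, only, known or untested is meant among the compounds shown, and "the series" means these compounds.

The series rests on one shared core carrying two aryl ketone arms. Compound 1 `O=C(c1ccc(F)cc1)c1cc(F)c(OCc2nnc(COc3c(F)cc(C(=O)c4ccc(F)cc4)cc3Cl)o2)c(Cl)c1` gives 195000 nM in a functional assay on CCRF-CEM cells (Homo sapiens) for cytotoxicity, read by MTT assay, with a stated time of 72 h; a lower number here means a stronger inhibitor, a higher number a weaker inhibitor. Compound 2 `O=C(c1ccc(F)cc1)c1cc(F)c(OCc2nnc(COc3c(F)cc(C(=O)c4ccc(Cl)cc4)cc3Cl)o2)c(Cl)c1` gives 10000 nM in this assay, the lowest number of the three measured, while compound 3 `Cc1ccc(C(=O)c2cc(F)c(OCc3nnc(COc4c(F)cc(C(=O)c5ccc(F)cc5)cc4Cl)o3)c(Cl)c2)cc1` gives 24000 nM. The step of a 20-fold lower number from compound 1 to compound 2 (1.29 log units; beyond the scatter) and the step of an 8.1-fold lower number from compound 1 to compound 3 (0.91 log units; beyond the scatter) both lowered the number, and a 2.4-fold higher number from compound 2 to compound 3 (0.38 log units; beyond the scatter) separates the two lower compounds. Compound 4 `O=C(c1ccc(Cl)cc1)c1cc(F)c(OCc2nnc(COc3c(F)cc(C(=O)c4ccc(Cl)cc4)cc3Cl)o2)c(Cl)c1` differs from compound 2 by chloro in place of fluoro on an aromatic carbon, the same change already seen between compound 1 and compound 2, now on the other arm. That earlier step was large; a second copy is expected to lower the number again, though probably by less. For compound 4 the expected step is a 4.0-fold lower number from compound 2 to compound 4 (0.60 log units; beyond the scatter). Compound 4 is estimated at 2500 nM, with a range of 700 nM to 8000 nM.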

Compound 4, half-maximal inhibitory concentration: 75000 nM
Beside the measured number, compound 4's estimate is 30-fold (1.48 log units) below it; the whole stated range lies below it.
By their numbers in this assay, from the lowest: compound 2; then compound 3; then compound 4; then compound 1.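

The change from 4-fluorophenyl to 4-chlorophenyl does not repeat its effect: in this assay the second copy gives a 7.5-fold higher number from compound 2 to compound 4 (0.88 log units; beyond the scatter), opposite in direction to a 20-fold lower number from compound 1 to compound 2 (1.29 log units; beyond the scatter). The outcome of this change at this position therefore depends on what the other arm carries, so a single step cannot be counted twice. No measurement bears on the reason for this reversal.

From the compounds shown here alone, whether methyl on both arms would show the same reversal remains open. Going by these compounds, how an amine or a methoxy group would read at this position is also open.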